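Cytotoxicity at the Assay Ceiling for Three Amides and a Fourth

The source may hold more compounds than are shown below. What is called first, only, known or untested is meant among the compounds shown, and "the series" means these compounds.

Compound 1, `CCOC(=O)CCCCCOc1cccc(CN(C(=O)c2ccc(-c3ccc4[nH]ccc4c3)cc2)C(C)C)c1`, gave > 26000 nM.
Compound 2, `CCOC(=O)CCCCCOc1cccc(CN(C(=O)c2ccc(-c3cccc(OCC)c3)cc2)C(C)C)c1`, gave > 22300 nM.
Compound 3, `CCOC(=O)CCCCCOc1cccc(CN(C(=O)c2ccc(-c3cc(OC)cc(OC)c3)cc2)C(C)C)c1`, gave > 26000 nM.

In an ADME assay on HepG2 cells (Homo sapiens) for cytotoxicity, read by CellTiter-Glo and resazurin assay, with a stated time of 72 h (on this read-out higher numbers stand for an effect only at larger amounts of compound and lower numbers for an effect already at smaller amounts), compound 1 reached only a limit of the assay, > 26000 nM, not a number. For compound 2 the result was likewise a limit, > 22300 nM. Compound 3 also gave only a limit, > 26000 nM, so its standing among the three is a ceiling rather than a measured point; all three sit at the limit of > 22300 nM in this assay, at which 1 of the 3 values shown sits, or (the limit of > 26000 nM in this assay, at which 2 of the 3 values shown sit). The steps between them, a step that the two limits leave unreadable from compound 1 to compound 2, a step that the two limits leave unreadable from compound 1 to compound 3 and a step that the two limits leave unreadable from compound 2 to compound 3, are therefore unreadable in size.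

Compound 4, `CCOC(=O)CCCCCOc1cccc(CN(C(=O)c2ccc(-c3cccc(CC(=O)O)c3)cc2)C(C)C)c1`, differs from compound 3 by 3-(carboxymethyl)phenyl in place of 3,5-dimethoxyphenyl on an aromatic carbon. Among the compounds with values here, no measured step bears on this change in a readable way, since every value shown is a limit. Three compounds sharing the core and reaching no effect up to the ceiling suggest that compound 4 is expected to behave the same, so the expected step that the limit leaves unreadable from compound 3 to compound 4 is none beyond the scatter. Compound 4 is thus estimated at 30000 nM in this assay, between 15000 nM and 60000 nM, most likely reported again as a limit.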

Compound 4, half-maximal effective concentration: > 26000 nM
Compound 4: no number, only a limit (the forecaster's own chance of this, stated with the estimate: 85%); the middle value does not contradict the limit.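

In this assay compound 4 gives > 26000 nM, which is a limit and not a number. Within the data shown here, compound 1, compound 2 and compound 3 also stand at limits, so no step from any of them to compound 4 can be read. The compounds shown leave open where each one's true half-maximal value lies, and whether exchanging the group on the shared core changes it.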